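Swapping dimethylamino for pyrrolidin-1-yl in compound 2

This account rests on a few compounds, and the source may have more. Where it says the series, first, only, none or still open, it means among the compounds named here.

Of the compounds shown here, two have been tested so far in a functional assay on the whole organism (stomach) with Canis familiaris (Canis lupus familiaris) as the target (on this read-out higher numbers stand for an effect only at larger amounts of compound and lower numbers for an effect already at smaller amounts), and only one gives a number. Compound 1 (`C/N=C(/CCSCc1ccc(CN(C)C)o1)NC#N`) reads > 10 mg/kg as a limit of the assay and not a number. Among the measured compounds shown here, compound 2 (`CN(C)Cc1cccc(OCCCC(=N)NC#N)c1`) gives 9 mg/kg as the only actual number so far. Compound 3 (`N#CNC(=N)CCCOc1cccc(CN2CCCC2)c1`) differs from compound 2 in one place (pyrrolidin-1-yl in place of dimethylamino on a saturated chain carbon bound to an aromatic carbon) with pyrrolidin-1-yl in place of dimethylamino on a saturated chain carbon bound to an aromatic carbon. For the measured compounds named here, no measured pair shows what this swap does, so the expected change in this assay is nothing beyond the usual scatter, and the estimated step of a 1.3-fold lower number from compound 2 to compound 3 (0.11 log units; within the scatter) stays small. Compound 3 is expected at 7 mg/kg within a range of 3 mg/kg to 18 mg/kg for now.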

Compound 3, dose for half-maximal effect: 3.5 mg/kg
Beside the measured number, compound 3's estimate is 2.0-fold (0.30 log units) above it, within the range that was stated.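

In this assay, the group on a saturated chain carbon bound to an aromatic carbon clearly matters: pyrrolidin-1-yl in place of dimethylamino gives a 2.6-fold lower number from compound 2 to compound 3 (0.41 log units; beyond the scatter). Among the compounds shown here, this single pair is the first readable step, and it shows the effect appearing at smaller amounts of compound with the ring-bearing group. Nothing given here accounts for this step.

On these data alone, it remains open how piperidin-1-yl, morpholin-4-yl or diethylamino would read at this place. One pair also cannot show whether the same swap would act alike on another core.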